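This account rests on a few compounds, and the source may have more. Where it says the series, first, only, none or still open, it means among the compounds named here.

Compound 1 `O=C(Oc1cccc2cccnc12)c1cc2c(cc1Cl)SC(N(c1ccc(F)cc1)S(=O)(=O)c1ccc(Br)s1)=NS2(=O)=O` and compound 3 `O=C(Oc1cccc2cccnc12)c1cc2c(cc1Cl)SC(N(c1ccc(F)cc1)S(=O)(=O)c1ccc(Cl)cc1)=NS2(=O)=O` share one core; compound 2 `COC(=O)c1cc2c(cc1Cl)SC(N(N(C)C)S(=O)(=O)c1ccc(Br)s1)=NS2(=O)=O` and the still unmeasured compound 4 `COC(=O)c1cc2c(cc1Cl)SC(N(N(C)C)S(=O)(=O)c1ccc(Cl)cc1)=NS2(=O)=O` share another. How the core of compound 2 differs from that of compound 1 is not broken down here. In a functional assay on A-427 cells (Homo sapiens) for cytotoxicity, with a stated time of 96 h (a higher number here means a weaker inhibitor of growth, a lower number a stronger inhibitor of growth), compound 1 gives 3400 nM and compound 3 gives 3100 nM. The step of a 1.1-fold lower number from compound 1 to compound 3 (0.04 log units; within the scatter) is the change (4-chlorophenyl in place of 5-bromothiophen-2-yl on a sulfonyl sulfur), and on this core it leaves the read-out essentially where it was. Going by the values given here, compound 2 gives 12000 nM, the highest of the three numbers and beyond the scatter from both compound 1 and compound 3; no counted step links it to either, so only the two values can be set side by side. Compound 4 carries exactly the same change at the same place as compound 3: 4-chlorophenyl in place of 5-bromothiophen-2-yl on a sulfonyl sulfur. Among the compounds with values here, the one measured instance of this change, a 1.1-fold lower number from compound 1 to compound 3 (0.04 log units; within the scatter), is the only guide, so for compound 4 a step of similar, small size is expected, a 1.1-fold lower number from compound 2 to compound 4 (0.04 log units; within the scatter). The expectation rests on a 1.1-fold lower number from compound 1 to compound 3 (0.04 log units; within the scatter) and on the reading of compound 2, 12000 nM. On that basis compound 4 is expected to read 11000 nM, between 5000 nM and 25000 nM.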

Compound 4, concentration for 50% growth inhibition: 10200 nM
Estimate against measurement, compound 4: 1.1-fold (0.03 log units) above; low and high end bracket the measured number.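

In this assay, 4-chlorophenyl in place of 5-bromothiophen-2-yl on the sulfonyl sulfur gives a 1.2-fold lower number from compound 2 to compound 4 (0.07 log units; within the scatter), so this change leaves the read-out within the scatter on this core too. Set beside the earlier step, the two results agree: the same change on two cores in this assay, a 1.1-fold lower number (0.04 log units; within the scatter) from compound 1 to compound 3 and a 1.2-fold lower number (0.07 log units; within the scatter) from compound 2 to compound 4, 1.1-fold (0.03 log units) apart, within the scatter of two such steps This shows that the exchange between these two aryl groups carries over between the two cores shown, but it rests on one pair per core and does not show that it would hold on a further core or for any other group on the sulfonyl sulfur.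

As far as these compounds go, both groups compared are halogen-bearing aromatic rings, so it remains open whether the read-out would also hold with a methyl group, a longer alkyl chain or a phenyl ring carrying an amine or a carboxylic acid on the sulfonyl sulfur. The parts in which the two cores differ are not varied one at a time in these compounds, so none of them can be assessed alone.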